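Changing the Chlorophenyl on the Sulfonyl of Compound 2

This account rests on a few compounds, and the source may have more. Where it says the series, first, only, none or still open, it means among the compounds named here.

Compound 1 `Cc1ccc2ncc(S(=O)(=O)c3ccc(F)cc3)c(N3CCC(C)CC3)c2c1` — 90%
Compound 2 `COc1ccc2ncc(S(=O)(=O)c3ccc(Cl)cc3)c(N3CCC(C)CC3)c2c1` — 91%

Of the compounds shown here, two have been measured in an assay on isolated protein for displacement of a labelled ligand from metabotropic glutamate receptor 5 (Homo sapiens), with a stated time of 60 min, tested at 1 uM; a higher number here means more inhibition at the concentration tested (going by the name of the read-out), a lower number less inhibition. In this assay compound 1 gives 90% and compound 2 gives 91%. The two numbers lie within the usual scatter of each other, so compound 2 does not stand apart from compound 1; both show strong inhibition at the concentration tested.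

Compound 3 `COc1ccc2ncc(S(=O)(=O)c3cccc(Cl)c3)c(N3CCC(C)CC3)c2c1` is not yet measured. It differs from compound 2 in one place: 3-chlorophenyl in place of 4-chlorophenyl on a sulfonyl sulfur. Among the measured compounds shown here, no measured pair shows a change of this kind, so the size of the step is not known from the data. For the measured compounds named here, with no comparable step to rest on, a modest fall is expected rather than none, a number 16 percentage points lower from compound 2 to compound 3 (beyond the scatter), since compound 2 already sits near the top of the scale at 91%. For compound 3 the inhibition is estimated at 75%, with a range from 40% to 95%.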

Compound 3, a percentage reported as inhibition, at one concentration (the size of the read-out at that concentration, not a potency): -3%
Compound 3: middle estimate off by 78 percentage points, on the high side; the whole stated range lies above it.
By their numbers in this assay, from the lowest: compound 3; then compounds 1 and 2 (each within the scatter of the next).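

In this assay, 3-chlorophenyl in place of 4-chlorophenyl on a sulfonyl sulfur gives a number 94 percentage points lower from compound 2 to compound 3 (beyond the scatter), a large step between two compounds that hold the same atoms joined differently. The near-equal values of compound 1 and compound 2 gave no hint of this, but the new pair shows that, at this place on the sulfonyl sulfur, inhibition at the concentration tested depends heavily on where the chlorine stands on the phenyl ring. The data offer no measured explanation for so large a step.

As far as these compounds go, whether a plain phenyl, a 2-chlorophenyl or a 3-methoxyphenyl on the sulfonyl sulfur would keep or lose the inhibition of compound 2 stays open. From the compounds shown here alone, it is also open whether 3-fluorophenyl would bring a similar loss on the core of compound 1.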